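The source may report more compounds than this note shows. Statements on the series, on what has been measured and on what is new or still open speak of the compounds shown alone.

Measured in an ADME assay on the whole organism (Mus musculus, strain CD1) for pharmacokinetics, at a dose of 10 mg/kg by the oral route; a higher number here means more compound in the circulation at the dose given, a lower number less compound in the circulation:

- Compound 1 `COc1cc(N2C(=O)C3(CCC3)N(c3ccc(OC4CCN(C)CC4)nc3)C2=S)cnc1C#N`: 1320 nM
- Compound 2 `CN1CCC(Oc2ccc(N3C(=S)N(c4cnc(C#N)c(C(F)(F)F)c4)C(=O)C34CCC4)cc2)CC1`: 980 nM

Compound 2, at 980 nM, stands within the scatter of compound 1, at 1320 nM, so these two numbers cannot be told apart in this assay. The structures of these two compounds differ in more than one place, and neither number isolates the effect of any single group.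

Compound 3 `N#Cc1ncc(N2C(=O)C3(CCC3)N(c3ccc(CN4CCNCC4)cc3)C2=S)cc1C(F)(F)F` has not yet been measured. It keeps the rest of compound 2 but carries (piperazin-1-yl)methyl in place of (1-methylpiperidin-4-yl)oxy on an aromatic carbon, para to a large group ((piperazin-1-yl)methyl in place of (1-methylpiperidin-4-yl)oxy on an aromatic carbon).

Among the measured compounds shown here, no measured pair shows what this exchange does, so the expectation is a judgement with wide uncertainty, starting from compound 2 at 980 nM. A moderate fall in this assay, somewhat beyond the scatter, is expected, and the estimated step is a 2.8-fold lower number from compound 2 to compound 3 (0.45 log units; beyond the scatter). The estimated value for compound 3 is 350 nM, with an expected range of 90 nM to 1200 nM.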

Compound 3, maximal plasma concentration: 840 nM
For compound 3 the middle estimate is 2.4-fold (0.38 log units) below the measured one; measured number inside the range.
By their numbers in this assay, from the lowest: compounds 3, 2 and 1 (each within the scatter of the next).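

In this assay, putting (piperazin-1-yl)methyl in place of (1-methylpiperidin-4-yl)oxy on this aromatic carbon, para to a large group, gives a 1.2-fold lower number from compound 2 to compound 3 (0.07 log units; within the scatter) and so leaves the read-out within the scatter. This position therefore accepts a change of both the ring and its link to the aromatic carbon, including a ring with two hetero atoms and a hydrogen-bond donor that the leaving group lacks, without a step that can be told from the scatter in this one pair. Nothing available here bears on why the number holds.

The exchange alters the ring and the link together, so the compounds do not show what either part contributes, and steps involving compound 1 cannot be read, as it differs from the others in more than one place. As far as these compounds go, it also remains open whether the same would hold for a morpholin-4-ylmethyl group or a (4-methylpiperazin-1-yl)methyl group at this carbon, which would carry no such donor, or for a longer chain between the ring and the aromatic carbon.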